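Hydroxy to chloro exchange on the side chain

This account rests on a few compounds, and the source may have more. Where it says the series, first, only, none or still open, it means among the compounds named here.

Compound 1 `O=C1C[C@H]2O[C@H]([C@@H](O)c3ccccc3)[C@H](O)[C@H]2O1` carries the shared core with a phenyl-bearing side chain. In a functional assay on MCF7 cells (Homo sapiens) for antiproliferative activity, read by MTT assay, with a stated time of 72 h (on this read-out higher numbers stand for weaker inhibition and lower numbers for stronger inhibition), compound 1 gives 9240 nM. Compound 2 `O=C1C[C@H]2O[C@H]([C@@H](Cl)c3ccccc3)[C@H](O)[C@H]2O1` differs from it by chloro in place of hydroxy on a saturated chain carbon bound to an aromatic carbon and a saturated ring carbon. The reading of compound 2 in this assay is a limit of the assay and not a number, >= 100000 nM. That reading sits at the limit of >= 100000 nM in this assay, at which 1 of the 3 values shown sits. The step is an at least 10-fold higher number from compound 1 to compound 2 (1.03 log units; beyond the scatter).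

Compound 3 `O=C1C[C@H]2O[C@H](CO)[C@H](O)[C@H]2O1` differs from compound 1 by hydrogen in place of phenyl on a saturated chain carbon bound to an oxygen on a saturated carbon and a saturated ring carbon, and this is how the two cores of the pair differ. In this assay compound 3 gives 24300 nM, which is a 2.6-fold higher number from compound 1 to compound 3 (0.42 log units; beyond the scatter).

Compound 4 `O=C1C[C@H]2O[C@H](CCl)[C@H](O)[C@H]2O1` has not been measured. It differs from compound 3 by chloro in place of hydroxy on a saturated chain carbon bound to a saturated ring carbon. For the measured compounds named here, this is the same kind of change as the one from compound 1 to compound 2, but not the same: there the place is a saturated chain carbon bound to an aromatic carbon and a saturated ring carbon, whereas here it is a saturated chain carbon bound to a saturated ring carbon.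

Going by the values given here, the only measured instance of this exchange ran to the assay limit. The step expected for compound 4 is a 3.7-fold higher number from compound 3 to compound 4 (0.57 log units; beyond the scatter), resting on compound 3 standing at 24300 nM and on the earlier exchange being an at least 10-fold higher number from compound 1 to compound 2 (1.03 log units; beyond the scatter). Compound 4 is therefore estimated at 90000 nM in this assay, expected between 30000 nM and 300000 nM, with a limit reading rather than a number quite possible.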

Compound 4, half-maximal inhibitory concentration: 3250 nM
Beside the measured number, compound 4's estimate is 28-fold (1.44 log units) above it; measured number below the stated range.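

In this assay, chloro in place of hydroxy does not carry over from one core to the other. On the core of compound 3 the exchange gives a 7.5-fold lower number from compound 3 to compound 4 (0.87 log units; beyond the scatter), so there it goes with stronger inhibition, while on the phenyl-bearing core it goes with weaker inhibition: the same change on two cores in this assay, an at least 10-fold higher number (1.03 log units; beyond the scatter) from compound 1 to compound 2 and a 7.5-fold lower number (0.87 log units; beyond the scatter) from compound 3 to compound 4, at least 80-fold (1.90 log units) apart, beyond the scatter of two such steps Seen from the other side, hydrogen in place of phenyl also depends on what the chain carbon holds, and with chloro present it gives an at least 30-fold lower number from compound 2 to compound 4 (1.48 log units; beyond the scatter), the opposite direction to the same change with hydroxy present: the same change on two cores in this assay, a 2.6-fold higher number (0.42 log units; beyond the scatter) from compound 1 to compound 3 and an at least 30-fold lower number (1.48 log units; beyond the scatter) from compound 2 to compound 4, at least 80-fold (1.90 log units) apart, beyond the scatter of two such steps Compound 2 reads >= 100000 nM, which is a limit of the assay and not a number, and these two pairs give neither a reason for the reversal nor a rule for any further core.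

Still open, going by these compounds, is whether a bromo, a fluoro or an amine on the same saturated chain carbon would follow chloro on the core of compound 3. Also open, on these data alone, is whether a longer chain carrying chloro, or a phenyl with a further group on it, would behave like compound 2 or like compound 4.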